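The source may report more compounds than this note shows. Statements on the series, on what has been measured and on what is new or still open speak of the compounds shown alone.

Measured compounds:
Compound 1 `N[C@]1(C(=O)O)[C@H]2[C@@H](C[C@H]1OCc1cccc(Cl)c1)[C@]2(F)C(=O)O` gives 3.28 nM
Compound 2 `N[C@]1(C(=O)O)[C@H]2[C@@H](C[C@H]1OCc1cccc(Br)c1)[C@]2(F)C(=O)O` gives 4.71 nM

Both numbers come from an assay on CHO cells for binding affinity to metabotropic glutamate receptor 2 (Rattus norvegicus); on this read-out lower numbers stand for stronger inhibition and higher numbers for weaker inhibition. Among the compounds with values here, compound 2 stands at the highest of the two numbers, but its only neighbour is compound 1, and the step of a 1.4-fold higher number from compound 1 to compound 2 (0.16 log units; within the scatter) is within the scatter, so the two compounds cannot be separated on this read-out.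

Compound 3 `N[C@]1(C(=O)O)[C@H]2[C@@H](C[C@H]1OCc1cccc(C(F)(F)F)c1)[C@]2(F)C(=O)O` has not yet been measured in this assay. It differs from compound 2 by trifluoromethyl in place of bromo on an aromatic carbon. Within the data shown here, the one measured step that bears on this change is the halogen swap at the same aromatic carbon, which produced no shift beyond the scatter. Among the measured compounds shown here, no measured step shows a trifluoromethyl group at this place, so the guide is indirect: an exchange of one small substituent for another at this position has so far left the number roughly where it was. Compound 3 is expected to give 6 nM in this assay, within a range of 2 nM to 18 nM. This estimate corresponds to a step of a 1.3-fold higher number from compound 2 to compound 3 (0.11 log units; within the scatter), expected to stay within the scatter.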

Compound 3, inhibition constant: 5.72 nM
Compound 3: middle estimate off by 1.0-fold (0.02 log units), on the high side; low and high end bracket the measured number.
By their numbers in this assay, from the lowest: compounds 1, 2 and 3 (each within the scatter of the next).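

In this assay, replacing bromo with trifluoromethyl gives a 1.2-fold higher number from compound 2 to compound 3 (0.08 log units; within the scatter), so going from 1 heavy atom to 4 heavy atoms at this aromatic carbon leaves no shift that can be read. The comparison with chloro gives a 1.7-fold higher number from compound 1 to compound 3 (0.24 log units; within the scatter), so compounds 1, 2 and 3 all lie within the scatter of one another, and the tolerance seen earlier for a swap between two halogens now extends to a non-halogen group of more heavy atoms. Within the data shown here, nothing available accounts for this flat result, and the data show only that the number stays put across these three groups.

The series shown has only chloro, bromo and trifluoromethyl at this place, so it remains open whether an amine, a carboxylic acid, a nitrile or a longer alkyl chain on the same aromatic carbon would keep the number in this range or move it beyond the scatter. As far as these compounds go, it is also open whether any of these groups would behave the same way on a different carbon of the aromatic ring.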